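Methyl in Place of Fluoro on the Aryl Ring

A few compounds are considered here, and "the series" means these few. Any claim that something is new, unique, unknown or untested is made for them only; others in the source may bear on it.

Compound 1 `CC(C(=O)N1CCN(c2ccccc2F)CC1)N1C(=O)CCC1=O` gives 50%
Compound 2 `CC(C(=O)N1CCN(c2cccc(F)c2)CC1)N1C(=O)CCC1=O` gives 50%

Among the compounds with values here, in a functional assay on the whole organism (strain Swiss) with Mus musculus as the target, in the maximal electroshock model, with a stated time of 0.5 h, at a dose of 300 mg/kg by the intraperitoneal route (a lower number here means a weaker effect, a higher number a stronger effect of the compound at the dose given), the only measured step, no change at the digits printed from compound 1 to compound 2 (within the scatter), lies within the scatter, so compound 2 stands level with its one neighbour. Compound 3 `Cc1cccc(N2CCN(C(=O)C(C)N3C(=O)CCC3=O)CC2)c1` differs from compound 2 in a single place: methyl in place of fluoro on an aromatic carbon. Within the data shown here, no measured step exchanges fluoro for methyl; the one known step, 3-fluorophenyl in place of 2-fluorophenyl, left the read-out unchanged and so offers only weak guidance. The expected step is therefore no change at the digits printed from compound 2 to compound 3 (within the scatter). Compound 3 is estimated at 50%, between 25% and 75%.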

Compound 3, a percentage reported as activity, at one dose (the size of the read-out at that dose, not a potency): 50%
Beside the measured number, compound 3's estimate shows no gap at the digits printed, within the range that was stated.
By their numbers in this assay, from the lowest: compounds 1, 2 and 3 (each within the scatter of the next).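

In this assay, exchanging fluoro for methyl on this aromatic carbon, meta to a large group, gives no change at the digits printed from compound 2 to compound 3 (within the scatter). The wider change to 3-methylphenyl gives no change at the digits printed from compound 1 to compound 3 (within the scatter), so the read-out holds with either of these one-heavy-atom groups at this place. Nothing available explains why the two groups read alike.

The compounds shown leave open whether a read-out at this level would survive a larger or differently built group here, such as an amine, a carboxylic acid or a longer chain. They also leave open how an unsubstituted phenyl would compare.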